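This account rests on a few compounds, and the source may have more. Where it says the series, first, only, none or still open, it means among the compounds named here.

Compound 1 `N#Cc1ccc(NC(=O)c2ccc3cccnc3c2O)c(F)c1` is tested in a functional assay on HL-60 cells (Homo sapiens) for cytotoxicity, read by luminescence and CellTiter-Glo, with a stated time of 3 days (a higher number here means a weaker inhibitor, a lower number a stronger inhibitor), where compound 1 gives 730 nM. Compound 3 `N#Cc1ccc(NC(=O)c2ccc3cccnc3c2O)cc1` gives 370 nM in this assay. The step of a 2.0-fold lower number from compound 1 to compound 3 (0.30 log units; within the scatter) corresponds to the change (hydrogen in place of fluoro on an aromatic carbon).

Compound 2 `O=C(Nc1ccc(C(F)(F)F)cc1)c1cc(Br)c(F)cc1O` gives 450 nM in this assay; the difference between its core and the core of compound 1 is not broken down here.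

Compound 4 `O=C(Nc1ccc(C(F)(F)F)cc1)c1cc(Br)ccc1O` has not yet been measured. It differs from compound 2 by hydrogen in place of fluoro on an aromatic carbon. This is the same kind of change as that from compound 1 to compound 3, though its surroundings differ: here the site is ortho to a bromo group, meta to a hydroxy group and para to a large group, whereas in compound 1 it is ortho to a large group and meta to a cyano group.

Resting on the step of a 2.0-fold lower number from compound 1 to compound 3 (0.30 log units; within the scatter) seen for compound 1, compound 4 is expected to show a step of a 1.4-fold lower number from compound 2 to compound 4 (0.13 log units; within the scatter) in this assay. Compound 4 is therefore estimated at 330 nM, with a likely range from 120 nM to 1000 nM.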

Compound 4, half-maximal inhibitory concentration: 580 nM
For compound 4 the middle estimate is 1.8-fold (0.24 log units) below the measured one; measured number inside the range.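

In this assay, hydrogen in place of fluoro on the core of compound 2 gives a 1.3-fold higher number from compound 2 to compound 4 (0.11 log units; within the scatter). Set beside the earlier step, the two results cannot be told apart: the same change on two cores in this assay, a 2.0-fold lower number (0.30 log units; within the scatter) from compound 1 to compound 3 and a 1.3-fold higher number (0.11 log units; within the scatter) from compound 2 to compound 4, 2.5-fold (0.41 log units) apart, within the scatter of two such steps. So nothing here shows that the core alters the outcome of this change, but with each step within the scatter and only two cores, this does not show that the change has a real effect on either core, or the same effect on both.

The compounds shown leave open how the change would behave at other ring sites or on further cores. They also leave open what a chloro, methoxy or amine group would do in place of fluoro at this site.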